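Swapping a basic piperazine for a methyl carbamate

The source may hold more compounds than are shown below. What is called first, only, known or untested is meant among the compounds shown, and "the series" means these compounds.

Measured compounds:
compound 1 `CCN1CCN(C[C@H]2CN(c3ccc(-n4cc(-c5ccccn5)cn4)c(F)c3)C(=O)O2)CC1` gives 2.19 in a physicochemical assay for lipophilicity, read by HPLC, measured as octanol-water partition; on this read-out lower numbers stand for lower lipophilicity and higher numbers for higher lipophilicity
compound 2 `O=C1O[C@@H](CN2CCCCC2)CN1c1ccc(-n2cc(-c3ccccn3)cn2)c(F)c1` gives 3.1 in this assay

Compound 1 stands lowest of the two measured numbers in this assay; its nearest neighbour is compound 2, which sits higher by the step of a number 0.91 log units higher from compound 1 to compound 2 (beyond the scatter). Among the compounds with values here, that one step is the only measured change at this position, and it concerns a different replacement, so it bears on the present case only loosely.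

Compound 3 `COC(=O)NC[C@H]1CN(c2ccc(-n3cc(-c4ccccn4)cn3)c(F)c2)C(=O)O1` differs from compound 1 by (methoxycarbonyl)amino in place of 4-ethylpiperazin-1-yl on a saturated chain carbon bound to a saturated ring carbon. The group that leaves is the same one that left in the step to compound 2, but what enters is a small, ring-free group carrying a hydrogen-bond donor rather than a saturated ring. The measured step upward to compound 2 therefore sets no direct expectation for compound 3; the carbamate is expected to sit at or somewhat below compound 1 in this assay, with a step of a number 0.29 log units lower from compound 1 to compound 3 (within the scatter). The account estimates compound 3 at 1.9, within a range from 1.3 to 2.5.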

Compound 3, partition coefficient: 2.03
Compound 3: the middle estimate sits 0.13 log units below what was measured; measured number inside the range.
By their numbers in this assay, from the lowest: compounds 3 and 1 (each within the scatter of the next); then compound 2.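

In this assay, giving up the 4-ethylpiperazin-1-yl group for the (methoxycarbonyl)amino group gives a number 0.16 log units lower from compound 1 to compound 3 (within the scatter) and so leaves the reading unresolved from that of the parent, even though the entering group has fewer heavy atoms, no ring and one hydrogen-bond donor. Measured against piperidin-1-yl at the same place, the same group gives a number 1.07 log units lower from compound 2 to compound 3 (beyond the scatter) in this assay, which adds a second large difference at this position to the one already seen and shows that a ring-free group can read alike with the ethylpiperazine while both stand apart from the piperidine. No supporting measurement accompanies these numbers, so the data give no account of why these two very different groups read alike.

The compounds shown leave open whether morpholin-4-yl, a free primary amine or an acetamide at this place would also read alike with compound 1 and compound 3. They also leave open whether a longer chain bearing the (methoxycarbonyl)amino group would keep that reading.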